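Swapping the ring on the sulfonyl in compound 3

The source may report more compounds than this note shows. Statements on the series, on what has been measured and on what is new or still open speak of the compounds shown alone.

Compound 3 `COc1cc2c(Oc3ccc(NC(=O)/C=C/S(=O)(=O)c4ccccc4F)cc3F)ccnc2cc1OCCCN1CCN(C)CC1` stands lowest of the three measured compounds in a functional assay on MKN-45 cells (Homo sapiens) for cytotoxicity, read by MTT assay, with a stated time of 72 h; on this read-out lower numbers stand for stronger inhibition and higher numbers for weaker inhibition: compound 3 gives 280 nM. Compound 1 `COc1cc2c(Oc3ccc(NC(=O)c4cn(-c5ccc(Cl)cc5)cn4)cc3F)ccnc2cc1OCCCN1CCN(C)CC1` gives 4110 nM, and compound 2 `COc1cc2c(Oc3ccc(NC(=O)c4cn(-c5cc(C)ccc5C)cn4)cc3F)ccnc2cc1OCCCN1CCC(C)CC1` gives 5650 nM. Within the data shown here, the only single-point step recorded, a 15-fold lower number from compound 1 to compound 3 (1.17 log units; beyond the scatter), replaces the whole group on the carbonyl carbon and is large, but it does not touch the part that changes now. Compound 4 `COc1ccc(S(=O)(=O)/C=C/C(=O)Nc2ccc(Oc3ccnc4cc(OCCCN5CCN(C)CC5)c(OC)cc34)c(F)c2)cc1` differs from compound 3 by 4-methoxyphenyl in place of 2-fluorophenyl on a sulfonyl sulfur. Among the measured compounds shown here, no measured step tests a change on this sulfonyl-bound ring, so a step beyond the scatter is not expected, and the estimated step is a 1.3-fold higher number from compound 3 to compound 4 (0.10 log units; within the scatter). Compound 4 is therefore expected to give 350 nM in this assay, within 110 nM to 1100 nM.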

Compound 4, half-maximal inhibitory concentration: 2770 nM
Beside the measured number, compound 4's estimate is 7.9-fold (0.90 log units) below it, outside the stated range (above it).
By their numbers in this assay, from the lowest: compound 3; then compounds 4, 1 and 2 (each within the scatter of the next, the first and the last beyond it).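

The ring on the sulfonyl sulfur is not a silent place: in this assay 4-methoxyphenyl in place of 2-fluorophenyl brings a 9.9-fold higher number from compound 3 to compound 4 (1.00 log units; beyond the scatter) and so weakens the compound beyond the scatter. The earlier step replaced the whole group on the carbonyl carbon, whereas this one shows that changing this ring alone can move the number. Nothing measured here accounts for the step.

One pair cannot separate losing the fluorine from gaining the methoxy. Plain phenyl, 4-fluorophenyl or 2-methoxyphenyl on the same sulfur would tell these apart.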